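Replacing 4-Methoxybenzyl with 3,7-Dimethylocta-2,6-dien-1-yl

The compounds below may be only part of what the source reports. "The series", "measured", "known", "first", "only" and "open" are said of these compounds alone.

For the measured compounds named here, in a functional assay on BT-474 cells (Homo sapiens) for inhibition, read by fluorescence, with a stated time of 72 h (on this read-out lower numbers stand for stronger inhibition of growth and higher numbers for weaker inhibition of growth), compound 1 (`COc1ccc(Cn2cnc3c(Nc4cccc(Cl)c4)nc(N[C@H]4CC[C@H](N)CC4)nc32)cc1`) gives 8200 nM and stands within the usual scatter of the only other measured compound. That compound, compound 2 (`COc1cc(Nc2nc(N[C@H]3CC[C@H](N)CC3)nc3c2ncn3CCC(C)C)cc(OC)c1`), gives 5900 nM in the same test, so these numbers do not separate the two. Compound 3 (`CC(C)=CCC/C(C)=C/Cn1cnc2c(Nc3cccc(Cl)c3)nc(N[C@H]3CC[C@H](N)CC3)nc21`) keeps the core of compound 1 and changes one group on a saturated chain carbon bound to an aromatic nitrogen: 2,6-dimethylhepta-1,5-dien-1-yl in place of 4-methoxyphenyl on a saturated chain carbon bound to an aromatic nitrogen (4-methoxybenzyl to 3,7-dimethylocta-2,6-dien-1-yl). Going by the values given here, no measured pair isolates this change, so the data give no direct guide to its effect. No step beyond the scatter is therefore expected in this assay in either direction. The estimated step is a 1.6-fold lower number from compound 1 to compound 3 (0.21 log units; within the scatter) and would remain within the scatter. For compound 3 the estimated value is 5000 nM with an expected range of 1800 nM to 14000 nM in this measurement.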

Compound 3, concentration for 50% growth inhibition: 4300 nM
Estimate against measurement, compound 3: 1.2-fold (0.07 log units) above; the range from low to high includes it.
By their numbers in this assay, from the lowest: compounds 3, 2 and 1 (each within the scatter of the next).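

For the compounds shown here, this pair is the first to isolate a change on the saturated chain carbon bound to an aromatic nitrogen: in this assay, 2,6-dimethylhepta-1,5-dien-1-yl in place of 4-methoxyphenyl gives a 1.9-fold lower number from compound 1 to compound 3 (0.28 log units; within the scatter) and does not separate the two groups. The entering group has no ring and no hydrogen-bond acceptor, so in this pair neither the six-membered aromatic ring nor the acceptor of 4-methoxyphenyl is needed to keep the reading within the scatter of compound 1. No measurement offered here explains this result.

The compounds shown leave open whether an amine, a carboxylic acid or a much shorter chain such as ethyl at this place would move the number beyond the scatter. They also leave open whether the same exchange would read alike on a core other than that of compound 1.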